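Swapping the halophenyl ring of compound 1

The source may report more compounds than this note shows. Statements on the series, on what has been measured and on what is new or still open speak of the compounds shown alone.

Measured so far in an assay (Equus caballus) for inhibition of Thromboxane-A synthase (Homo sapiens), using microsomes; on this read-out higher numbers stand for weaker inhibition and lower numbers for stronger inhibition:
Compound 1, `O=C(O)CCCC/C=C(/c1ccc(Br)cc1)c1cccnc1`: 82 nM
Compound 2, `CCOC(=O)CCCC/C=C(\c1ccccc1)c1cccnc1`: 600 nM

Compound 1 has the lower of the two numbers in this assay, and compound 2 gives the higher one, a gap that lies beyond the usual scatter. Within the data shown here, compound 2 differs from compound 1 in more than one place, so no single step between measured compounds is available, and the measured pair says nothing direct about what a change of the halophenyl ring alone does.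

Compound 3, `O=C(O)CCCC/C=C(\c1cccnc1)c1cccc(F)c1`, has not been measured in this assay. It differs from compound 1 in one place: 3-fluorophenyl in place of 4-bromophenyl on a double-bonded chain carbon bound to an aromatic carbon and a double-bonded chain carbon. Both rings are of the same size and carry one halogen each, so the change is modest in kind. Among the measured compounds shown here, with no step of this kind on record, the expectation for this assay is a small move, if any, staying within or only slightly beyond the scatter, and on the weaker side. Compound 3 is therefore estimated at 150 nM, with a likely range from 50 nM to 500 nM, which means an expected step of a 1.8-fold higher number from compound 1 to compound 3 (0.26 log units; within the scatter).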

Compound 3, half-maximal inhibitory concentration: 55 nM
Compound 3: middle estimate off by 2.7-fold (0.44 log units), on the high side; measured number inside the range.
By their numbers in this assay, from the lowest: compounds 3 and 1 (each within the scatter of the next); then compound 2.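

In this assay, putting 3-fluorophenyl in place of 4-bromophenyl on a double-bonded chain carbon bound to an aromatic carbon and a double-bonded chain carbon gives a 1.5-fold lower number from compound 1 to compound 3 (0.17 log units; within the scatter) and so leaves the two compounds indistinguishable on this read-out. Among these compounds, this is the first single-place step on record at this position, and it shows that this particular swap of one halogen-bearing phenyl ring for another, with the rest of compound 1 unchanged, produces no change that can be told from the scatter. Nothing measured here explains why these two rings give matching numbers.

The step changes the halogen and its place on the ring together, so the two compounds shown cannot separate the effect of either change alone, and a matching result for one pair of halogens does not extend to other substituents. Also open, from the compounds shown here alone, is whether this position would stay as undemanding with a group that is not a halogen, such as a methoxy group or an amine on the phenyl ring in place of the fluorine or bromine.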